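The source may report more compounds than this note shows. Statements on the series, on what has been measured and on what is new or still open speak of the compounds shown alone.

Compound 1 `CC(C)=CCCN(C)C1CCN(CCCc2c[nH]c3ccc(-n4cnnc4)cc23)CC1`: 24 nM
Compound 2 `O[C@@H]1Cc2ccccc2[C@H]1NC1CCN(CCCc2c[nH]c3ccc(-n4cnnc4)cc23)CC1`: 210 nM

In an assay on CHO cells for displacement of a labelled ligand from 5-hydroxytryptamine receptor 1B (Homo sapiens) (on this read-out higher numbers stand for weaker inhibition and lower numbers for stronger inhibition), compound 1 gives the lowest of these two numbers; the nearest is compound 2, reached through an 8.8-fold higher number from compound 1 to compound 2 (0.94 log units; beyond the scatter). Compound 3 `CN(Cc1ccc(S(C)(=O)=O)cc1)C1CCN(CCCc2c[nH]c3ccc(-n4cnnc4)cc23)CC1` differs from compound 1 by 4-(methylsulfonyl)phenyl in place of 3-methylbut-2-en-1-yl on a saturated chain carbon bound to an amine nitrogen. Among the measured compounds shown here, only that one measured step bears on this change, and it swaps a different group on the amine, so it is a loose guide: it shows that altering what the amine carries can shift this assay by a modest amount. The number for compound 3 is expected to be 40 nM, within 10 nM to 200 nM, an estimated step of a 1.7-fold higher number from compound 1 to compound 3 (0.22 log units; within the scatter).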

Compound 3, half-maximal inhibitory concentration: 140 nM
The estimate for compound 3 lay 3.5-fold (0.54 log units) below the measured number; the measured number falls inside the stated range.
By their numbers in this assay, from the lowest: compound 1; then compounds 3 and 2 (each within the scatter of the next).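

In this assay, 4-(methylsulfonyl)phenyl in place of 3-methylbut-2-en-1-yl gives a 5.8-fold higher number from compound 1 to compound 3 (0.77 log units; beyond the scatter). With the methyl on the amine kept, this position still allows measurable inhibition with an aromatic ring in place of the open chain, though inhibition is weaker than with that chain. No evidence at hand explains the size of this step. Still open, on these data alone, is whether the weakening comes from the ring itself or from the methylsulfonyl group on it. An unsubstituted phenyl at the same place would separate the two.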